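This account rests on a few compounds, and the source may have more. Where it says the series, first, only, none or still open, it means among the compounds named here.

Compound 1 `COc1ccc(-c2[nH]c3ccccc3c2/C=C(\C#N)S(=O)(=O)c2ccccc2)cc1`: 2300 nM
Compound 2 `COc1ccc2[nH]c(-c3ccccc3)c(C=C(C#N)C#N)c2c1`: 2400 nM
Compound 3 `O=C(/C(=C\c1c(-c2ccccc2)[nH]c2ccccc12)S(=O)(=O)c1ccccc1)c1ccccc1`: 5000 nM

Three compounds were tested in a functional assay on HOP-92 cells (Homo sapiens) for inhibition, read by sulforhodamine B assay, with a stated time of 48 h; on this read-out higher numbers stand for weaker inhibition of growth and lower numbers for stronger inhibition of growth. Compound 1 gives 2300 nM, compound 2 gives 2400 nM, and compound 3 gives 5000 nM. Compound 3 therefore carries the highest of the three numbers; its nearest neighbour is compound 2 and its furthest is compound 1, and both gaps lie beyond the usual scatter, so compound 3 shows the weakest growth inhibition of the three.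

The next compound, compound 4 `N#C/C(=C\c1c(-c2ccccc2)[nH]c2ccccc12)S(=O)(=O)c1ccccc1`, is not yet measured in this assay. Its structure differs from compound 3 in one place: cyano in place of benzoyl on a double-bonded chain carbon bound to a double-bonded chain carbon and a sulfonyl sulfur. Within the data shown here, no step between two measured compounds matches this change, so no directly measured precedent exists. Compound 1, which also carries cyano together with the phenylsulfonyl group on the double-bonded chain, gives 2300 nM, a lower number than compound 3. On that basis compound 4 is expected to give a modestly lower number than compound 3, a step of a 1.8-fold lower number from compound 3 to compound 4 (0.25 log units; within the scatter) close to the edge of the scatter. Compound 4 is estimated at 2800 nM, with a likely range from 1200 nM to 6500 nM.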

Compound 4, concentration for 50% growth inhibition: 10300 nM
The estimate for compound 4 lay 3.7-fold (0.57 log units) below the measured number, outside the stated range (above it).
By their numbers in this assay, from the lowest: compounds 1 and 2 (each within the scatter of the next); then compound 3; then compound 4.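

Within this assay the change of benzoyl to cyano on a double-bonded chain carbon bound to a double-bonded chain carbon and a sulfonyl sulfur gives a 2.1-fold higher number from compound 3 to compound 4 (0.31 log units; beyond the scatter) and so shows that, on this core, benzoyl at this place goes with stronger growth inhibition than cyano. Hydrogen in place of methoxy on an aromatic carbon gives a 4.5-fold higher number from compound 1 to compound 4 (0.65 log units; beyond the scatter) and shows that, with cyano at the chain carbon, the methoxy group goes with stronger growth inhibition than hydrogen. Nothing measured here accounts for either step.

As far as these compounds go, it remains open whether a carboxylic acid or an ester at this chain carbon would give a number nearer that of benzoyl or cyano. Also open, from the compounds shown here alone, is whether methoxy would bring a similar step in a compound that keeps benzoyl.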